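The compounds below may be only part of what the source reports. "The series", "measured", "known", "first", "only" and "open" are said of these compounds alone.

Measured compounds:
compound 1 `Cc1ncoc1C(=O)NCc1ccc2cc(C(=O)NO)sc2c1F` in a functional assay on HCT-116 cells (Homo sapiens) for antiproliferative activity, read by resazurin assay, with a stated time of 5 days (a lower number here means a stronger inhibitor, a higher number a weaker inhibitor), gives 210 nM;
compound 2 `O=C(NCc1ccc2cc(C(=O)NO)sc2c1F)c1ccc[nH]1` gives 300 nM;
compound 3 `COc1ccccc1C(=O)NCc1ccc2cc(C(=O)NO)sc2c1F` gives 1200 nM.

Compound 1 has the lowest number of the three, but its gap to compound 2 is within the scatter; only compound 3 stands clearly apart, as shown by a 5.7-fold higher number from compound 1 to compound 3 (0.76 log units; beyond the scatter) and a 4.0-fold higher number from compound 2 to compound 3 (0.60 log units; beyond the scatter).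

Compound 4 `COc1ccc(C(=O)NCc2ccc3cc(C(=O)NO)sc3c2F)cc1` differs from compound 1 by 4-methoxyphenyl in place of 4-methyl-1,3-oxazol-5-yl on a carbonyl carbon. Within the data shown here, the closest precedent is compound 3, where 2-methoxyphenyl replaced the same 4-methyl-1,3-oxazol-5-yl and gave a 5.7-fold higher number from compound 1 to compound 3 (0.76 log units; beyond the scatter); no measured step covers 4-methoxyphenyl itself. A step in the same direction, perhaps somewhat smaller, is therefore expected: a 2.9-fold higher number from compound 1 to compound 4 (0.46 log units; beyond the scatter). Compound 4 is estimated at 600 nM, in the range 200 nM to 2000 nM.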

Compound 4, half-maximal inhibitory concentration: 50 nM
Compound 4: the middle estimate sits 12-fold (1.08 log units) above what was measured; the measured number lies below the stated range.
By their numbers in this assay, from the lowest: compound 4; then compounds 1 and 2 (each within the scatter of the next); then compound 3.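

In this assay, the two methoxyphenyl groups on the carbonyl carbon do not behave alike: 4-methoxyphenyl in place of 2-methoxyphenyl gives a 24-fold lower number from compound 3 to compound 4 (1.38 log units; beyond the scatter). A phenyl group here can therefore outdo both five-membered aromatic rings, with a 4.2-fold lower number from compound 1 to compound 4 (0.62 log units; beyond the scatter) and a 6.0-fold lower number from compound 2 to compound 4 (0.78 log units; beyond the scatter), although compound 3 goes against this. No measurement at hand explains the difference.

The compounds shown leave open whether the methoxy group is needed for this gain, since an unsubstituted phenyl would separate its share from that of the ring. Going by these compounds, it is also open how a 4-aminophenyl or 4-carboxyphenyl group would compare.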